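Tert-Butyl Replaces Bromo on a Fused Ring

The source may report more compounds than this note shows. Statements on the series, on what has been measured and on what is new or still open speak of the compounds shown alone.

Of the compounds shown here, three have so far been measured in a functional assay on HEK293 cells for antagonist activity at transient receptor potential cation channel subfamily V member 1 (Homo sapiens), read by calcium flux; a lower number here means a stronger inhibitor, a higher number a weaker inhibitor. Compound 1 `CCC(c1ccccn1)c1c(Cl)c(Cl)cc2[nH]c(=O)c(=O)[nH]c12` gives 1400 nM, compound 2 `CC(C)(C)c1ccc(NC(=O)c2ccc(SC(F)(F)F)cc2)cc1` gives 253 nM, and compound 3 `FC(F)C(F)(F)Oc1ccc(-c2nc3cc(Br)ccc3[nH]2)cc1` gives 380 nM. Compound 3 thus holds the second highest of the three numbers. Its nearest neighbour is compound 2, whose number lies within the scatter of that of compound 3; compound 1 lies beyond the scatter at a higher number and is therefore the weaker inhibitor of that pair.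

Compound 4 `CC(C)(C)c1ccc2[nH]c(-c3ccc(OC(F)(F)C(F)F)cc3)nc2c1` has not yet been measured. It differs from compound 3 in one place: tert-butyl in place of bromo on an aromatic carbon. The change sits on an aromatic carbon of a six-membered aromatic ring of carbon only, part of a fused system of two rings, meta to a fused ring and para to a fused ring.

For the measured compounds named here, no measured pair shows this exchange, and compound 2, the only measured compound carrying a tert-butyl, rests on a different core, so its number of 253 nM is only a loose guide. A small step toward a lower number, probably within the scatter, is expected. Compound 4 is therefore expected to give about 250 nM, within a range from 80 nM to 800 nM. This estimate corresponds to an expected step of a 1.5-fold lower number from compound 3 to compound 4 (0.18 log units; within the scatter) in this assay.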

Compound 4, half-maximal inhibitory concentration: 477 nM
Beside the measured number, compound 4's estimate is 1.9-fold (0.28 log units) below it; measured number inside the range.
By their numbers in this assay, from the lowest: compounds 2, 3 and 4 (each within the scatter of the next); then compound 1.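

In this assay, tert-butyl in place of bromo on this aromatic carbon, meta to a fused ring and para to a fused ring, gives a 1.3-fold higher number from compound 3 to compound 4 (0.10 log units; within the scatter). For the compounds shown here, this is the first pair that differs in one place, and it shows that the two groups cannot be told apart at this position, even though tert-butyl has 4 heavy atoms and bromo has 1. No evidence is available that bears on the reason for this result.

Still open, as far as these compounds go, is whether an amine, a carboxylic acid or a methoxy group on the same carbon would shift the number beyond the scatter. Also open, from the compounds shown here alone, is whether this exchange would give a similar step on a different core, such as that of compound 1.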